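Swapping the ring on the amide carbonyl of compound 3

The compounds below may be only part of what the source reports. "The series", "measured", "known", "first", "only" and "open" are said of these compounds alone.

Of the compounds shown here, three sharing one core have been tested in a functional assay on NCI-H1975 cells (Homo sapiens) for antiproliferative activity, read by MTT assay, with a stated time of 72 h; a lower number here means a stronger inhibitor, a higher number a weaker inhibitor. Compound 1 `COc1cc(F)c(NC(=O)c2ccnc(Cl)c2)cc1Nc1nccc(-c2cn(C)c3ccccc23)n1` gives 4330 nM. Compound 2 `COc1ccc(C(=O)Nc2cc(Nc3nccc(-c4cn(C)c5ccccc45)n3)c(OC)cc2F)nc1` gives 16800 nM, and compound 3 `COc1cc(F)c(NC(=O)c2ccccn2)cc1Nc1nccc(-c2cn(C)c3ccccc23)n1` gives 16500 nM. Compound 3 therefore stands second highest of the three numbers; its value and that of compound 2 lie within the scatter of each other, while a 3.8-fold higher number from compound 1 to compound 3 (0.58 log units; beyond the scatter) separates it from compound 1.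

The next compound, compound 4 `COc1cc(F)c(NC(=O)c2nccn2C)cc1Nc1nccc(-c2cn(C)c3ccccc23)n1`, differs from compound 3 in one place: 1-methyl-1H-imidazol-2-yl in place of pyridin-2-yl on a carbonyl carbon. For the measured compounds named here, the steps that bear on this are those that also exchanged the ring on the carbonyl carbon, namely a 3.9-fold higher number from compound 1 to compound 2 (0.59 log units; beyond the scatter) and a 3.8-fold higher number from compound 1 to compound 3 (0.58 log units; beyond the scatter), both of modest size; the step of a 1.0-fold lower number from compound 2 to compound 3 (0.01 log units; within the scatter), which only removed a methoxy from that ring, stayed within the scatter. An exchange of the whole ring has thus moved this assay modestly, with no evidence on which direction a five-membered ring would take. Compound 4 is therefore expected to give a number close to compound 3, with a 1.4-fold lower number from compound 3 to compound 4 (0.14 log units; within the scatter) as the estimated step; the estimate for compound 4 is 12000 nM, between 3000 nM and 45000 nM.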

Compound 4, half-maximal inhibitory concentration: 10600 nM
The estimate for compound 4 lay 1.1-fold (0.05 log units) above the measured number; measured number inside the range.
By their numbers in this assay, from the lowest: compound 1; then compounds 4, 3 and 2 (each within the scatter of the next).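

In this assay, a five-membered ring on this carbonyl carbon cannot be told apart from the six-membered rings of compounds 2 and 3: a 1.6-fold lower number from compound 3 to compound 4 (0.19 log units; within the scatter) and a 1.6-fold lower number from compound 2 to compound 4 (0.20 log units; within the scatter) both stay inside the usual scatter. The 2-chloropyridin-4-yl group of compound 1 still stands apart, since a 2.4-fold higher number from compound 1 to compound 4 (0.39 log units; beyond the scatter) is beyond the scatter, so the change of ring size alone gives no readable step, while compound 1 remains separate from all three others. Nothing available explains why these compounds group this way.

Going by these compounds, it remains open whether a chlorine on 1-methyl-1H-imidazol-2-yl would bring the number closer to that of compound 1. On these data alone, the effect of a group other than an aromatic ring on this carbonyl carbon, such as a piperidine or a longer chain ending in an amine, also remains open.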